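This account rests on a few compounds, and the source may have more. Where it says the series, first, only, none or still open, it means among the compounds named here.

Three compounds share one core and differ only in the group carried on an aromatic nitrogen. In a functional assay on PC-3 cells (Homo sapiens) for inhibition, read by MTT assay, with a stated time of 72 h (on this read-out higher numbers stand for weaker inhibition and lower numbers for stronger inhibition), compound 1 `CC(C)n1ncc2c(C(=O)NCc3cn(-c4cccc(F)c4)nn3)cccc21` gives 36100 nM. In this assay compound 2 `Cc1ccc(-n2cc(CNC(=O)c3cccc4c3cnn4C(C)C)nn2)cc1` gives 39000 nM. In this assay compound 3 `CC(C)n1ncc2c(C(=O)NCc3cn(Cc4ccccc4)nn3)cccc21` gives 4420 nM. Compound 3 stands lowest of the three: the steps of an 8.2-fold lower number from compound 1 to compound 3 (0.91 log units; beyond the scatter) and an 8.8-fold lower number from compound 2 to compound 3 (0.95 log units; beyond the scatter) both lie beyond the scatter, whereas a 1.1-fold higher number from compound 1 to compound 2 (0.03 log units; within the scatter) shows that exchanging one substituted phenyl for another barely moved the number.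

Compound 4 `CC(C)n1ncc2c(C(=O)NCc3cn(Cc4ccc(C#N)cc4)nn3)cccc21` differs from compound 3 by cyano in place of hydrogen on an aromatic carbon. Within the data shown here, no measured step adds a group to the benzyl itself, so the only guide is that 4-methylphenyl against 3-fluorophenyl gave a step within the scatter. A small step is therefore expected, a 1.0-fold higher number from compound 3 to compound 4 (0.01 log units; within the scatter). Compound 4 is estimated at 4500 nM, within a range from 1500 nM to 14000 nM.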

Compound 4, half-maximal inhibitory concentration: 18200 nM
The estimate for compound 4 lay 4.0-fold (0.61 log units) below the measured number, and the stated range ends below it.
By their numbers in this assay, from the lowest: compound 3; then compounds 4, 1 and 2 (each within the scatter of the next, the first and the last beyond it).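

On the benzyl ring, substitution does matter: in this assay, cyano para to a large group gives a 4.1-fold higher number from compound 3 to compound 4 (0.61 log units; beyond the scatter), so a single added group cancels much of the advantage of benzyl over the phenyl groups. What remains of that advantage is small, with a 2.1-fold lower number from compound 2 to compound 4 (0.33 log units; beyond the scatter) and a 2.0-fold lower number from compound 1 to compound 4 (0.30 log units; within the scatter). Nothing available here explains this loss.

From the compounds shown here alone, whether the loss is specific to cyano stays open, since a methoxy group, an amine or a carboxylic acid at the same place could give a different number.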